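A few compounds are considered here, and "the series" means these few. Any claim that something is new, unique, unknown or untested is made for them only; others in the source may bear on it.

In an assay on CHO cells for displacement of a labelled ligand from adenosine receptor A3 (Homo sapiens), read by scintillation counting, with a stated time of 120 min, tested at 1 uM (on this read-out higher numbers stand for more inhibition at the one concentration tested (going by the name of the read-out) and lower numbers for less inhibition), three compounds sharing one core were compared, differing only in the group carried on a saturated chain carbon bound to a sulfur. Compound 1 `N#Cc1c(N)nc(SCc2nc3ccccc3[nH]2)c(C#N)c1-c1ccc(OCC2CC2)cc1` gives 1%. Compound 2 `N#Cc1c(N)nc(SCn2cncn2)c(C#N)c1-c1ccc(OCC2CC2)cc1` gives 1%. Compound 3 `N#Cc1c(N)nc(SCC(=O)NCO)c(C#N)c1-c1ccc(OCC2CC2)cc1` gives 8%. On these numbers compound 3 stands with the highest of the three figures, yet the steps of a number 7 percentage points higher from compound 1 to compound 3 (within the scatter) and a number 7 percentage points higher from compound 2 to compound 3 (within the scatter) lie within the scatter, as does no change at the digits printed from compound 1 to compound 2 (within the scatter), so the three compounds are not separated in this assay.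

Compound 4 `N#Cc1c(N)nc(SCc2cccnc2)c(C#N)c1-c1ccc(OCC2CC2)cc1` continues the series at the same place: pyridin-3-yl in place of (hydroxymethyl)carbamoyl on a saturated chain carbon bound to a sulfur. Among the measured compounds shown here, the steps that bear on this change are the exchanges of groups on that chain carbon already seen, and each of them stayed within the scatter, with every number small. Compound 1 and compound 2, each carrying an aromatic ring there, gave the lowest values, and the ring entering in compound 4 is again aromatic. No step beyond the scatter is therefore expected for compound 4, and the step of a number 6 percentage points lower from compound 3 to compound 4 (within the scatter) is estimated to stay within it. Compound 4 is expected to give 2% in this assay, with a range from 0% to 10%.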

Compound 4, a percentage reported as inhibition, at one concentration (the size of the read-out at that concentration, not a potency): 19%
The estimate for compound 4 lay 17 percentage points below the measured number, and the stated range ends below it.
By their numbers in this assay, from the lowest: compounds 1, 2 and 3 (each within the scatter of the next); then compound 4.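

In this assay, the group on a saturated chain carbon bound to a sulfur is now seen to move the number beyond the scatter: pyridin-3-yl in place of (hydroxymethyl)carbamoyl gives a number 11 percentage points higher from compound 3 to compound 4 (beyond the scatter), the first such step at this position among the compounds shown. An aromatic ring at this place does not by itself settle the result, as the same group gives a number 18 percentage points higher from compound 2 to compound 4 (beyond the scatter) in place of 1H-1,2,4-triazol-1-yl and a number 18 percentage points higher from compound 1 to compound 4 (beyond the scatter) in place of 1H-benzimidazol-2-yl, so aromatic groups at this one place are separated from each other as well. Nothing available gives a reason for this difference between the groups.

The compounds shown leave open whether the ring nitrogen of pyridin-3-yl is needed, which a phenyl group at the same place would test, and whether its place in the ring counts, which pyridin-2-yl and pyridin-4-yl would test. Also open, going by these compounds, is how a carboxylic acid or an amine on this chain carbon would read, and, with only one concentration tested, what potency lies behind any of these numbers.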